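Replacing an arylamino group with pyrrolidin-1-yl on the shared core

The source may hold more compounds than are shown below. What is called first, only, known or untested is meant among the compounds shown, and "the series" means these compounds.

Compound 1 `Cc1ccc(NC2=CC(=O)c3nc4n(c3C2=O)[C@H]2OC[C@@H](O)[C@H]2OC4)cc1`, compound 2 `COc1ccc(NC2=CC(=O)c3c(nc4n3[C@H]3OC[C@@H](O)[C@H]3OC4)C2=O)cc1` and compound 3 `CCOc1ccc(NC2=CC(=O)c3c(nc4n3[C@H]3OC[C@@H](O)[C@H]3OC4)C2=O)cc1` share one core and differ only in the group on the double-bonded ring carbon. In a functional assay on MGC-803 cells (Homo sapiens) for inhibition, read by sulforhodamine B assay (a lower number here means a stronger inhibitor, a higher number a weaker inhibitor), compound 1 gives 1420 nM, compound 2 gives 2150 nM and compound 3 gives 2090 nM; compound 1 has the lowest of the three numbers, yet all three lie within the scatter of one another. Going by the values given here, the only single-point step measured, a 1.0-fold lower number from compound 2 to compound 3 (0.01 log units; within the scatter), does not touch the change now in view. Compound 4 `O=C1C=C(N2CCCC2)C(=O)c2c1nc1n2[C@H]2OC[C@@H](O)[C@H]2OC1` carries pyrrolidin-1-yl in place of (4-methylphenyl)amino on a double-bonded ring carbon. Among the compounds with values here, no measured step bears on this exchange, so the expected size of the step is uncertain; the estimate leans toward a somewhat weaker inhibitor. Compound 4 is therefore expected to give 3000 nM, between 800 nM and 12000 nM, a step of a 2.1-fold higher number from compound 1 to compound 4 (0.32 log units; beyond the scatter).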

Compound 4, half-maximal inhibitory concentration: > 16000 nM
Compound 4 was reported as a limit; the forecaster's own chance of this, stated with the estimate: 10%; middle value at least 5.3-fold (0.72 log units) from the limit.
By their numbers in this assay, from the lowest: compounds 1, 3 and 2 (each within the scatter of the next). At a limit, above all of these: compound 4.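

In this assay, compounds 1, 2 and 3, all arylamino compounds, lay within the scatter of one another, so they gave no sign that this position could tolerate less. Pyrrolidin-1-yl in place of (4-methylphenyl)amino on the double-bonded ring carbon brings an at least 11-fold higher number from compound 1 to compound 4 (1.05 log units; beyond the scatter), so the exchange is a large one. Compound 4 is read at a limit and not at a number: the limit of > 16000 nM in this assay, at which 1 of the 4 values shown sits. The exchange removes the six-membered aromatic ring and the hydrogen-bond donor together, and this one step cannot separate the two. As far as these compounds go, how a cyclopentylamino group, which keeps the amine hydrogen without the aromatic ring, would compare with compound 1 remains open.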